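A few compounds are considered here, and "the series" means these few. Any claim that something is new, unique, unknown or untested is made for them only; others in the source may bear on it.

In a functional assay on MDA-MB-231 cells (Homo sapiens) for antiproliferative activity, with a stated time of 4 days (on this read-out lower numbers stand for stronger inhibition and higher numbers for weaker inhibition), compound 1 `COc1ccc(-c2[nH]c3ccc(OC)cc3c2C=O)cc1` gives 260 nM and compound 2 `COc1ccc(-c2[nH]c3ccc(C)cc3c2C=O)cc1` gives 86 nM while compound 3 `COc1ccc(-c2[nH]c3ccc(C(C)C)cc3c2C=O)cc1` gives 29 nM and stands lowest of the three. The next change leads to compound 4 `CCCCc1ccc2[nH]c(-c3ccc(OC)cc3)c(C=O)c2c1` and is butyl in place of isopropyl on an aromatic carbon with butyl in place of isopropyl on an aromatic carbon. Bearing on it are a 3.0-fold lower number from compound 1 to compound 2 (0.48 log units; beyond the scatter) and a 3.0-fold lower number from compound 2 to compound 3 (0.47 log units; beyond the scatter) as well as the whole run a 9.0-fold lower number from compound 1 to compound 3 (0.95 log units; beyond the scatter) and all are modest and beyond the scatter. For the measured compounds named here, no butyl compound has been measured, so this trend may not carry on. A small further fall, possibly no larger than the scatter, is expected, given a 3.0-fold lower number from compound 2 to compound 3 (0.47 log units; beyond the scatter) in that direction. The expected step is a 1.8-fold lower number from compound 3 to compound 4 (0.26 log units; within the scatter) in this read-out. For compound 4 the estimated value is 16 nM with 5 nM to 50 nM as the expected range.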

Compound 4, half-maximal inhibitory concentration: 6.7 nM
The estimate for compound 4 lay 2.4-fold (0.38 log units) above the measured number; the range from low to high includes it.
By their numbers in this assay, from the lowest: compound 4; then compound 3; then compound 2; then compound 1.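

In this assay the fall in numbers does not stop at isopropyl: butyl on this aromatic carbon still gives a step beyond the scatter (a 4.3-fold lower number from compound 3 to compound 4 (0.64 log units; beyond the scatter)). For the compounds shown here, measured against the earlier compounds, the butyl compound extends the gain further (a 13-fold lower number from compound 2 to compound 4 (1.11 log units; beyond the scatter); a 39-fold lower number from compound 1 to compound 4 (1.59 log units; beyond the scatter)), and none of the four compounds goes against this order. No evidence here bears on the reason for the gain. As far as these compounds go, whether a longer chain such as hexyl lowers the number further remains open, as does the effect of an amine at the end of the chain.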